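Shared core series: thiophen-3-yl in place of pyridin-3-yl

This account rests on a few compounds, and the source may have more. Where it says the series, first, only, none or still open, it means among the compounds named here.

Measured so far in an assay on CHO cells for displacement of a labelled ligand from adenosine receptor A3 (Homo sapiens), read by scintillation counting, tested at 10 uM; on this read-out higher numbers stand for more inhibition at the one concentration tested (going by the name of the read-out) and lower numbers for less inhibition:
compound 1, `CC(C)(C)Cc1csc(N)c1C(=O)c1cccc(Cl)c1`, 8%
compound 2, `CC(C)(C)Cc1c(-c2cccnc2)sc(N)c1C(=O)c1ccc(Cl)cc1`, 1%

Compound 2 gives the lowest of the two numbers in this assay, and compound 1 lies close to it, within the usual scatter of repeated measurements. The two values therefore allow no order between them; both stand at the low end of the scale, with little displacement at the one concentration tested.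

Compound 3, `CC(C)(C)Cc1c(-c2ccsc2)sc(N)c1C(=O)c1ccc(Cl)cc1`, differs from compound 2 in one place: thiophen-3-yl in place of pyridin-3-yl on an aromatic carbon. For the measured compounds named here, no step between measured compounds is available to calibrate this change. With compound 2 already near the floor of the read-out and compound 1 no different within the scatter, the step from compound 2 to compound 3 is expected to be none beyond the scatter, a number 4 percentage points higher from compound 2 to compound 3 (within the scatter). Compound 3 is accordingly expected to give 5%, with a range from -5% to 15%.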

Compound 3, a percentage reported as inhibition, at one concentration (the size of the read-out at that concentration, not a potency): 4%
Estimate against measurement, compound 3: 1 percentage points above, within the range that was stated.
By their numbers in this assay, from the lowest: compounds 2, 3 and 1 (each within the scatter of the next).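

In this assay, replacing pyridin-3-yl with thiophen-3-yl on the aromatic carbon next to the ring sulfur gives a number 3 percentage points higher from compound 2 to compound 3 (within the scatter). For the compounds shown here, this is the first reading at this position: exchanging a six-membered aromatic ring with one nitrogen for a five-membered aromatic ring with one sulfur leaves the number at the low end of the scale, so this exchange yields no readable gain in displacement at the one concentration tested. No measurement bearing on why the two values stay together is available.

On these data alone, whether a non-aromatic group at this carbon, such as a carboxylic acid or a dimethylamino group, would lift the number remains open. As far as these compounds go, with both values this low, it is also open whether differences between aromatic rings at this position could be read in this assay at all.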